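Compound 3 to Compound 4: A Benzylsulfanyl Replacement

The compounds below may be only part of what the source reports. "The series", "measured", "known", "first", "only" and "open" are said of these compounds alone.

Compound 1 `O=C(COCc1ccccc1)N1CCN(c2ccc(F)cc2)CC1` gives 1100 nM; compound 2 `Cc1cc(Cl)ccc1N1CCN(C(=O)COCc2ccncc2)CC1` gives 240 nM; compound 3 `O=C(COCc1ccncn1)N1CCN(c2ccc(Cl)cc2Cl)CC1` gives 2800 nM.

In a functional assay on HEK293 cells for positive allosteric modulation of metabotropic glutamate receptor 5 (Homo sapiens), read by FLIPR and calcium flux (a higher number here means that more compound is needed for the effect, a lower number that less compound is needed), compound 3 stands with the highest number of the three. Compound 1 is its nearest neighbour and compound 2 its furthest, and both gaps lie beyond the usual scatter. Compound 4 `O=C(CSCc1ccccc1)N1CCN(c2ccc(Cl)cc2Cl)CC1` differs from compound 3 in one place: benzylsulfanyl in place of (pyrimidin-4-yl)methoxy on a saturated chain carbon bound to a carbonyl carbon. No measured pair isolates this change, so the expectation rests only on the three numbers shown; compound 3 stands above compound 1, which also carries a six-membered aromatic ring of carbon only at this position and gives 1100 nM. The step from compound 3 to compound 4 is therefore expected to be modest and toward a lower number, a 1.9-fold lower number from compound 3 to compound 4 (0.27 log units; within the scatter). Compound 4 is estimated at 1500 nM, within a range of 500 nM to 5000 nM.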

Compound 4, half-maximal effective concentration: 7100 nM
Compound 4: the middle estimate sits 4.7-fold (0.68 log units) below what was measured; measured number outside the range, above it.
By their numbers in this assay, from the lowest: compound 2; then compound 1; then compound 3; then compound 4.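

In this assay, the exchange on a saturated chain carbon bound to a carbonyl carbon gives a 2.5-fold higher number from compound 3 to compound 4 (0.40 log units; beyond the scatter) and so moves the number beyond the usual scatter. This position therefore responds to the change even though the leaving and entering groups have the same heavy-atom count, each with one six-membered aromatic ring. No measurement shown explains this step.

The exchange replaces both the ring nitrogens and the chain oxygen, so the compounds leave open which of these replacements accounts for the step. As far as these compounds go, how an amine or a carboxylic acid on this chain would read also remains open.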